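A few compounds are considered here, and "the series" means these few. Any claim that something is new, unique, unknown or untested is made for them only; others in the source may bear on it.

Three compounds have been measured in an ADME assay on microsomes (Mus musculus) for metabolic stability; a higher number here means faster removal of the compound, a lower number slower removal:

- compound 1 `CNC(=O)[C@@H]1CCCN1S(=O)(=O)c1ccc(Cl)c(COc2cccc3c(C(F)(F)F)cc(C)nc23)c1Cl`, 1380 mL/min/kg
- compound 2 `Cc1cc(C(F)(F)F)c2cccc(OCc3c(Cl)ccc(S(=O)(=O)N4CCC[C@H]4CO)c3Cl)c2n1`, 1630 mL/min/kg
- compound 3 `Cc1cc(C(F)(F)F)c2cccc(OCc3c(Cl)ccc(S(=O)(=O)N4CC[C@@H](N(C)C)C4)c3Cl)c2n1`, 867 mL/min/kg

Compound 3, at 867 mL/min/kg, is separated from the other two only by small steps, a 1.6-fold lower number from compound 1 to compound 3 (0.20 log units; within the scatter) and a 1.9-fold lower number from compound 2 to compound 3 (0.27 log units; within the scatter). The three values therefore cannot be put in a firm order.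

The next compound, compound 4 `Cc1cc(C(F)(F)F)c2cccc(OCc3c(Cl)ccc(S(=O)(=O)N4CCC(CCO)CC4)c3Cl)c2n1`, has 4-(2-hydroxyethyl)piperidin-1-yl in place of 3-(dimethylamino)pyrrolidin-1-yl on a sulfonyl sulfur. The same two steps bear on this change, since each also replaces the group on the sulfonyl sulfur, and neither left the scatter. The exchange between the two groups of compound 1 and compound 2 was just as small, a 1.2-fold higher number from compound 1 to compound 2 (0.07 log units; within the scatter). Within the data shown here, no measured compound carries the entering group, so any reading across to it is tentative. Compound 2 is the nearest guide, as it also has a hydroxyl-bearing group on a saturated ring, and it stands at 1630 mL/min/kg. A modest rise is therefore expected, but nothing beyond the scatter. The expected change is a 1.4-fold higher number from compound 3 to compound 4 (0.16 log units; within the scatter) in size. For compound 4 the estimated clearance is 1250 mL/min/kg, with an expected range of 650 mL/min/kg to 2300 mL/min/kg.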

Compound 4, clearance: 1080 mL/min/kg
Estimate against measurement, compound 4: 1.2-fold (0.06 log units) above; the range from low to high includes it.
By their numbers in this assay, from the lowest: compounds 3, 4, 1 and 2 (each within the scatter of the next).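

In this assay, the first six-membered ring on the sulfonyl sulfur, 4-(2-hydroxyethyl)piperidin-1-yl, gives a number that cannot be separated from any of the three five-membered rings: a 1.2-fold higher number from compound 3 to compound 4 (0.10 log units; within the scatter), a 1.5-fold lower number from compound 2 to compound 4 (0.18 log units; within the scatter) and a 1.3-fold lower number from compound 1 to compound 4 (0.11 log units; within the scatter). The four groups at this position now include a ring carrying a methylcarbamoyl group, two carrying a hydroxyl-bearing chain and one carrying dimethylamino, and no step among the listed compounds leaves the scatter, so this set gives no sign that ring size or the kind of substituent shifts clearance in these microsomes. No measurement is available that would explain the result.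

The step from compound 3 to compound 4 changes the ring size, the substituent and its ring location together, so the compounds shown cannot separate the contribution of each. On these data alone, it also remains open whether any group on the sulfonyl sulfur can move the number beyond the scatter, such as a piperidine bearing a carboxylic acid, a morpholine, or a longer hydroxyalkyl chain, or whether a change to the shared core would be needed.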